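The source may hold more compounds than are shown below. What is called first, only, known or untested is meant among the compounds shown, and "the series" means these compounds.

In a functional assay on the whole organism for inhibition, with Scenedesmus acutus as the target (on this read-out lower numbers stand for stronger inhibition and higher numbers for weaker inhibition), compound 1 `O=C(O)c1cc(N2C(=O)C3=C(CCCC3)C2=O)ccc1Cl` gives > 100000 nM, which is a limit of the assay and not a number. The butyl ester, compound 2 `CCCCOC(=O)c1cc(N2C(=O)C3=C(CCCC3)C2=O)ccc1Cl`, gives 6310 nM, and the isobutyl ester, compound 3 `CC(C)COC(=O)c1cc(N2C(=O)C3=C(CCCC3)C2=O)ccc1Cl`, gives 977 nM. Compound 3 therefore holds the lower of the two actual numbers. Compound 4 `CCCCCCCCOC(=O)c1cc(N2C(=O)C3=C(CCCC3)C2=O)ccc1Cl` is the next to be tested, and it differs from compound 3 as follows: heptyl in place of isopropyl on a saturated chain carbon bound to an oxygen next to a carbonyl group. In words, this is heptyl in place of isopropyl on a saturated chain carbon bound to an oxygen next to a carbonyl group. Two large steps, an at least 15-fold lower number from compound 1 to compound 2 (1.19 log units; beyond the scatter) and an at least 100-fold lower number from compound 1 to compound 3 (2.01 log units; beyond the scatter), show what replacing the hydrogen with a chain did, but they say little about chain length. Among the compounds with values here, no measured pair tests a longer chain. Within the data shown here, the nearest guide is the modest step of a 6.5-fold lower number from compound 2 to compound 3 (0.81 log units; beyond the scatter), the one comparison between an unbranched and a branched chain, and compound 4 carries an unbranched chain like compound 2. A modest move toward a higher number, meaning weaker inhibition, is therefore expected, though with wide uncertainty. The expected change is a 4.1-fold higher number from compound 3 to compound 4 (0.61 log units; beyond the scatter). Compound 4 is estimated at 4000 nM, with an expected range of 700 nM to 30000 nM.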

Compound 4, half-maximal inhibitory concentration: > 100000 nM
Compound 4: only a limit was reported; the forecaster's own chance of this, stated with the estimate: 8%; middle value at least 25-fold (1.39 log units) away from the limit.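

In this assay compound 4 gives > 100000 nM, which is a limit of the assay and not a number. Even read as a limit, the result shows that a chain on this oxygen does not by itself carry a lower number, since lengthening it can undo the gain seen with the shorter esters: there is an at least 100-fold higher number from compound 3 to compound 4 (2.01 log units; beyond the scatter), and there is also an at least 15-fold higher number from compound 2 to compound 4 (1.19 log units; beyond the scatter). The octyl ester therefore stands well apart from both the isobutyl and the butyl ester, while the step between compound 1 and compound 4 cannot be read, as both values are limits: the limit of > 100000 nM in this assay, at which 2 of the 4 values shown sit.

The compounds shown leave open where between the butyl chain of compound 2 and the octyl chain of compound 4 the number rises, and whether a pentyl or hexyl ester would stay close to compound 2 or already reach the limit. They also leave open whether the branching that separates compound 3 from compound 2 would matter on a longer chain, such as a branched octyl chain, and how an amide in place of the ester would behave.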